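The source may report more compounds than this note shows. Statements on the series, on what has been measured and on what is new or still open speak of the compounds shown alone.

In a functional assay on KYSE-410 cells (Homo sapiens) for antiproliferative activity, read by MTT assay, with a stated time of 72 h (on this read-out lower numbers stand for stronger inhibition and higher numbers for weaker inhibition), compound 1 `O=C(Nc1cccc(F)c1)c1cc(=O)[nH]c2cc(Br)ccc12` gives 7300 nM and compound 2 `O=C(Nc1cccc(F)c1)c1cc(=O)[nH]c2cc(-c3cccc(F)c3)ccc12` gives 10900 nM, which places the two within the scatter of each other. Compound 3 `O=C(Nc1cccc(F)c1)c1cc(=O)[nH]c2cc(C3=CCOCC3)ccc12` differs from compound 2 on an aromatic carbon of the shared core: a group of 6 heavy atoms (5 carbon, 1 oxygen; one six-membered non-aromatic ring with 1 hetero atom) in place of a group of 7 heavy atoms (6 carbon, 1 fluorine; one six-membered aromatic ring of carbon only), on an aromatic carbon. Going by the values given here, the one measured step at this carbon, a 1.5-fold higher number from compound 1 to compound 2 (0.17 log units; within the scatter), also exchanges the group there and stays within the scatter. No step beyond the scatter is therefore expected in this assay. The estimated change is a 1.2-fold lower number from compound 2 to compound 3 (0.08 log units; within the scatter). For compound 3 the expected value is 9000 nM, with an estimated range of 3500 nM to 25000 nM.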

Compound 3, half-maximal inhibitory concentration: 12100 nM
Estimate against measurement, compound 3: 1.3-fold (0.13 log units) below, within the range that was stated.
By their numbers in this assay, from the lowest: compounds 1, 2 and 3 (each within the scatter of the next).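

In this assay, the six-membered non-aromatic ring with its hetero atom gives a 1.1-fold higher number from compound 2 to compound 3 (0.05 log units; within the scatter) and a 1.7-fold higher number from compound 1 to compound 3 (0.22 log units; within the scatter). Bromo, 3-fluorophenyl and this ring therefore read alike at this aromatic carbon, so neither the loss of ring aromaticity nor the added hydrogen-bond acceptor produces a step beyond the scatter in these compounds. No evidence bearing on the reason for this is available. Open, going by these compounds, is whether an amine or a carboxylic acid on this carbon would move the number beyond the scatter. Also open, on these data alone, is whether any group here can give a clearly lower number.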